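Fluorine shift on the aniline of compound 1

This account rests on a few compounds, and the source may have more. Where it says the series, first, only, none or still open, it means among the compounds named here.

Among the measured compounds shown here, in a functional assay on HT-29 cells (Homo sapiens) for cytotoxicity, read by sulforhodamine B assay (on this read-out higher numbers stand for weaker inhibition and lower numbers for stronger inhibition), compound 1 `C=C1[C@@H](OC(C)=O)C[C@@H]2[C@](C)(CO[Si](C)(C)C(C)(C)C)[C@H](OC(C)=O)CC[C@@]2(C)[C@@H]1C[C@@H](Nc1ccc(F)cc1)C1=CCOC1=O` gives 4940 nM, the lower of the two numbers so far. Compound 2 `C=C1[C@@H](OC(C)=O)C[C@@H]2[C@](C)(COC=O)[C@H](OC(C)=O)CC[C@@]2(C)[C@@H]1C[C@@H](Nc1ccccc1C(=O)O)C1=CCOC1=O` gives 28700 nM, a gap beyond the scatter. Compound 3 `C=C1[C@@H](OC(C)=O)C[C@@H]2[C@](C)(CO[Si](C)(C)C(C)(C)C)[C@H](OC(C)=O)CC[C@@]2(C)[C@@H]1C[C@@H](Nc1ccccc1F)C1=CCOC1=O` carries 2-fluorophenyl in place of 4-fluorophenyl on an amine nitrogen. For the measured compounds named here, no measured pair isolates this change, so the expectation rests on compound 1 at 4940 nM. The estimated step of a 1.1-fold higher number from compound 1 to compound 3 (0.02 log units; within the scatter) is expected to stay within the scatter, with no favoured direction. For compound 3 the expected value is 5200 nM, with an estimated range of 2400 nM to 11500 nM.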

Compound 3, half-maximal inhibitory concentration: 3710 nM
Compound 3: the middle estimate sits 1.4-fold (0.15 log units) above what was measured; the range from low to high includes it.
By their numbers in this assay, from the lowest: compounds 3 and 1 (each within the scatter of the next); then compound 2.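

Among the compounds shown here, with 2-fluorophenyl in place of 4-fluorophenyl on the amine nitrogen, this assay reads a 1.3-fold lower number from compound 1 to compound 3 (0.12 log units; within the scatter) and this is the first single-place comparison. The two fluorine placements on this phenyl ring cannot be told apart on this read-out, so the fluorine position alone gives no handle here. No supporting data bear on the reason for this result.

Open, on these data alone, is how much this amine substituent matters at all. A plain phenyl, a methoxyphenyl or a pyridine at the same place would test whether the read-out responds to the aromatic group itself.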